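A few compounds are considered here, and "the series" means these few. Any claim that something is new, unique, unknown or untested is made for them only; others in the source may bear on it.

Measured so far in a functional assay on DU-145 cells (Homo sapiens) for inhibition, read by trypan blue exclusion, with a stated time of 96 h; a higher number here means a weaker inhibitor of growth, a lower number a stronger inhibitor of growth:
compound 1, `Cc1ccc(CS/C(=C/c2ccc(C)s2)C(=O)c2ccc(Cl)cc2)cc1`, 50000 nM;
compound 2, `Cc1ccc(/C=C(/Sc2ccc(F)cc2)C(=O)c2ccc(Cl)cc2)s1`, 25000 nM.

For the measured compounds named here, compound 2 stands at the lower of the two numbers in this assay, but its only neighbour is compound 1, and the step of a 2.0-fold lower number from compound 1 to compound 2 (0.30 log units; within the scatter) lies within the scatter, so nothing separates the two. Compound 3, `COc1ccc(S/C(=C/c2ccc(C)s2)C(=O)c2ccc(Cl)cc2)cc1`, is the next member of the series. It differs from compound 2 as follows: methoxy in place of fluoro on an aromatic carbon. Going by the values given here, no measured step replaces one substituent with another on this aryl group; the single step in hand, a 2.0-fold lower number from compound 1 to compound 2 (0.30 log units; within the scatter), exchanged the whole group on a sulfur and moved the number by an amount within the scatter. On that basis no shift beyond the scatter is expected for compound 3, and the step of no change at the digits printed from compound 2 to compound 3 (within the scatter) is set accordingly. Compound 3 is therefore estimated at 25000 nM in this assay, with a range of 8000 nM to 80000 nM.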

Compound 3, concentration for 50% growth inhibition: 50000 nM
The estimate for compound 3 lay 2.0-fold (0.30 log units) below the measured number; the range from low to high includes it.
By their numbers in this assay, from the lowest: compounds 2, 1 and 3 (each within the scatter of the next).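

For the compounds shown here, the first substituent exchange on this aryl group, methoxy in place of fluoro para to a large group, leaves the result within the scatter in this assay (a 2.0-fold higher number from compound 2 to compound 3 (0.30 log units; within the scatter)). Replacing the 4-methylbenzyl group on the sulfur with 4-methoxyphenyl also stays within the scatter (no change at the digits printed from compound 1 to compound 3 (within the scatter)), so compounds 1, 2 and 3 cannot be separated in this assay, and neither change shows any effect on growth inhibition here. No supporting data bear on this result.

As far as these compounds go, it remains open whether an amine or a carboxylic acid at this aromatic carbon would shift the number beyond the scatter. A longer alkoxy chain in place of methoxy poses the same question.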